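Swapping trifluoromethyl for trifluoromethoxy on a chromone core

A few compounds are considered here, and "the series" means these few. Any claim that something is new, unique, unknown or untested is made for them only; others in the source may bear on it.

Of the compounds shown here, three have been tested in a functional assay on HeLa cells (Homo sapiens) for antiproliferative activity, read by MTT assay, with a stated time of 12 h; a higher number here means a weaker inhibitor, a lower number a stronger inhibitor. Compound 1 `COc1ccc2c(=O)cc(/C=C/c3ccc(OC(F)(F)F)cc3)oc2c1` gives 9900 nM, and compound 2 `COc1cccc2oc(/C=C/c3ccc(OC(F)(F)F)cc3)cc(=O)c12` gives 9100 nM. Compound 3 `COc1cc(OC)c2c(=O)cc(/C=C/c3ccc(C(F)(F)F)cc3)oc2c1` gives 19000 nM, the highest of the three numbers; the gap to compound 1 lies within the usual scatter of repeated measurements, while the gap to compound 2 lies beyond it. No single-change pair among these measured compounds exists, so no step can be read directly from them.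

Compound 4 `COc1cc(OC)c2c(=O)cc(/C=C/c3ccc(OC(F)(F)F)cc3)oc2c1` is the next compound, and it has not yet been measured. It differs from compound 3 in one place only: trifluoromethoxy in place of trifluoromethyl on an aromatic carbon. Compounds 1 and 2 already carry the trifluoromethoxy group on their own cores, but their cores are not that of compound 3, so the size of this change cannot be inferred from them. Going by the values given here, with no directly comparable step available, the expected step from compound 3 to compound 4 in this assay is a 1.4-fold lower number from compound 3 to compound 4 (0.13 log units; within the scatter), which is to say no change beyond the scatter. Compound 4 is therefore estimated at 14000 nM, with a range from 6000 nM to 32000 nM.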

Compound 4, half-maximal inhibitory concentration: > 40000 nM
Compound 4: only a limit was reported (the forecaster's own chance of this, stated with the estimate: 10%); middle value at least 2.8-fold (0.45 log units) away from the limit.
By their numbers in this assay, from the lowest: compounds 2, 1 and 3 (each within the scatter of the next, the first and the last beyond it). At a limit, above all of these: compound 4.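

In this assay compound 4 gives only a limit, > 40000 nM, and not a number. Read against its trifluoromethyl partner on the same core, trifluoromethoxy in place of trifluoromethyl, para to a large group, gives an at least 2.1-fold higher number from compound 3 to compound 4 (0.32 log units; beyond the scatter), so here the swap goes with a weaker inhibitor rather than a stronger one. With trifluoromethoxy kept, methoxy in place of hydrogen on an aromatic carbon also goes with a weaker inhibitor, in both an at least 4.0-fold higher number from compound 1 to compound 4 (0.60 log units; beyond the scatter) and an at least 4.3-fold higher number from compound 2 to compound 4 (0.64 log units; beyond the scatter).

On these data alone, the full size of all three steps stays open, since each can be read only as a lower bound: the limit of > 40000 nM in this assay, at which 1 of the 4 values shown sits. Also open is how an amine or a carboxylic acid in the same place on the aromatic ring would compare with trifluoromethyl.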